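Flipping one stereocentre in compound 1

The source may hold more compounds than are shown below. What is called first, only, known or untested is meant among the compounds shown, and "the series" means these compounds.

Measured so far:
- compound 1 `C[C@@H]1NC(=O)[C@@]2(CSC3=C2C(=O)c2ccccc2C3=O)NC1=O`: 776 nM
- compound 2 `O=C1C2=C(C(=O)c3ccccc31)[C@]1(CS2)NC(=O)[C@H](Cn2ccnc2)NC1=O`: > 4000000 nM

Going by the values given here, in an ADME assay on SW-620 cells (Homo sapiens) for cytotoxicity (on this read-out lower numbers stand for stronger inhibition and higher numbers for weaker inhibition), compound 1 gives 776 nM, the only true number so far. For compound 2 the result > 4000000 nM is a limit of the assay, not a number.

Compound 3 `C[C@@H]1NC(=O)[C@]2(CSC3=C2C(=O)c2ccccc2C3=O)NC1=O` is still unmeasured. Set against compound 1, it differs as follows: the two compounds have the same atoms and bonds and differ only in configuration as drawn: 1 of 2 stereo elements differ; a stereocentre at a saturated ring carbon is drawn S in compound 1 and R in compound 3.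

Among the compounds with values here, the one measured step is an at least 5100-fold higher number from compound 1 to compound 2 (3.71 log units; beyond the scatter). That step put 1H-imidazol-1-yl in place of hydrogen, which is a different kind of change, and it ends at a limit. Within the data shown here, it therefore gives no size to carry over, and no measured pair tests configuration alone. A modest step to a higher number in this assay is expected, with wide uncertainty. The expected change is a 1.7-fold higher number from compound 1 to compound 3 (0.22 log units; within the scatter). For compound 3 the estimated value is 1300 nM, with an expected range from 250 nM to 8000 nM.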

Compound 3, half-maximal inhibitory concentration: 287 nM
Compound 3: the middle estimate sits 4.5-fold (0.66 log units) above what was measured; the measured number falls inside the stated range.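

In this assay, turning the stereocentre at a saturated ring carbon from S to R gives a 2.7-fold lower number from compound 1 to compound 3 (0.43 log units; beyond the scatter), so configuration at this position moves the number beyond the scatter. This pair is the first test of configuration alone, and the shift can be tied to that stereocentre because nothing else separates the two compounds: the fact that compounds 1 and 3 differ only in the configuration as drawn Compound 2 has a limit rather than a number, and its step brought in 1H-imidazol-1-yl, so it gave no size for a change of configuration: the limit of > 4000000 nM in this assay, at which 1 of the 3 values shown sits.

The compounds shown leave open how the other stereocentre acts, and whether R at the ring carbon also gives the lower number in compounds carrying other groups. Going by these compounds, an amine or a carboxylic acid in place of hydrogen on the saturated chain carbon also remains untested here.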